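A Methoxy Group Added to the Core of Compound 1

The source may report more compounds than this note shows. Statements on the series, on what has been measured and on what is new or still open speak of the compounds shown alone.

The set rests on compound 1 `c1cncc(-c2nc3ccccc3n2C2CC2)c1`. In an assay on V79 cells for inhibition of cytochrome P450 11B2, mitochondrial (Homo sapiens), read by HTRF, with a stated time of 1 h (a higher number here means a weaker inhibitor, a lower number a stronger inhibitor), compound 1 gives 49 nM, the lowest of the two numbers recorded, with compound 2 nearest to it. Compound 2 `Fc1cccc2nc(-c3cccnc3)n(C3CC3)c12` carries fluoro in place of hydrogen on an aromatic carbon, and in this assay compound 2 gives 107 nM; the step of a 2.2-fold higher number from compound 1 to compound 2 (0.34 log units; beyond the scatter). Compound 3 `CS(=O)(=O)c1ccc2c(c1)nc(-c1cccnc1)n2C1CC1` carries methylsulfonyl in place of hydrogen on an aromatic carbon. In this assay compound 3 reaches only > 1000 nM, which is a limit of the assay and not a number. That entry is the limit of > 1000 nM in this assay, at which 1 of the 3 values shown sits, so the step of an at least 20-fold higher number from compound 1 to compound 3 (1.30 log units; beyond the scatter) is a bound rather than a measured size. Compound 4 `COc1ccc2nc(-c3cccnc3)n(C3CC3)c2c1` is not yet measured; it differs from compound 1 by methoxy in place of hydrogen on an aromatic carbon. Both measured steps bear on this change, each replacing a ring hydrogen with a substituent: the fluoro step was modest, the methylsulfonyl step large. Set against the steps of a 2.2-fold higher number from compound 1 to compound 2 (0.34 log units; beyond the scatter) and an at least 20-fold higher number from compound 1 to compound 3 (1.30 log units; beyond the scatter), a rise of intermediate size is expected for compound 4, namely a 4.1-fold higher number from compound 1 to compound 4 (0.61 log units; beyond the scatter). Compound 4 is estimated at 200 nM, between 70 nM and 600 nM.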

Compound 4, half-maximal inhibitory concentration: 24 nM
Estimate against measurement, compound 4: 8.3-fold (0.92 log units) above; the measured number lies below the stated range.
By their numbers in this assay, from the lowest: compound 4; then compound 1; then compound 2. At a limit, above all of these: compound 3.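

In this assay, methoxy in place of hydrogen on this aromatic carbon gives a 2.0-fold lower number from compound 1 to compound 4 (0.31 log units; beyond the scatter) and is the only one of the three listed replacements of a ring hydrogen to lower the number. The other two changes went upward, with a 2.2-fold higher number from compound 1 to compound 2 (0.34 log units; beyond the scatter) for fluoro and an at least 20-fold higher number from compound 1 to compound 3 (1.30 log units; beyond the scatter) for methylsulfonyl, the latter being a bound set by a limit of the assay. Substitution of a ring hydrogen on the core of compound 1 therefore need not cost inhibition, and nothing in the data given accounts for the lower number of compound 4.

No other group is shown at this place, so it remains open whether the gain belongs to methoxy or to the carbon it occupies. A hydroxy group, an amine or a longer chain such as ethoxy on that carbon would help to separate the two.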